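The source may report more compounds than this note shows. Statements on the series, on what has been measured and on what is new or still open speak of the compounds shown alone.

In a functional assay on HCT-15 cells (Homo sapiens) for antiproliferative activity, read by MTT assay, with a stated time of 72 h (on this read-out lower numbers stand for stronger inhibition and higher numbers for weaker inhibition), compound 1 `COc1cc(-c2nccn2-c2ccc3[nH]ccc3c2)cc(OC)c1OC` gives 4600 nM and compound 2 `COc1cc(-c2nccn2-c2ccc(Br)cc2)cc(OC)c1OC` gives 11700 nM as its half-maximal inhibitory concentration. Compound 3 `COc1ccc(C(=O)Nc2cc(OC)c(OC)c(OC)c2)cc1[N+](=O)[O-]` at 2000 nM holds the lowest of these three numbers, and its gaps to both others lie beyond the scatter. Compound 4 `COc1ccc(C(=O)Nc2cc(OC)c(OC)c(OC)c2)cc1N` differs from compound 3 by amino in place of nitro on an aromatic carbon with amino in place of nitro on an aromatic carbon, ortho to a methoxy group. Going by the values given here, no measured pair shows this change, so the expectation in this assay rests on the structural change alone and remains uncertain. A modest move toward stronger inhibition is expected, the estimated step being a 2.0-fold lower number from compound 3 to compound 4 (0.30 log units; within the scatter) with wide uncertainty. Compound 4 is estimated at 1000 nM within an expected range from 150 nM to 6000 nM in this assay once measured.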

Compound 4, half-maximal inhibitory concentration: > 100000 nM
Compound 4 ended at the assay's limit (the forecaster's own chance of this, stated with the estimate: 10%); middle value at least 100-fold (2.00 log units) away from the limit.
By their numbers in this assay, from the lowest: compound 3; then compound 1; then compound 2. At a limit, above all of these: compound 4.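

In this assay, amino in place of nitro on an aromatic carbon, ortho to a methoxy group, gives an at least 50-fold higher number from compound 3 to compound 4 (1.69 log units; beyond the scatter). The earlier compounds shown here held no such pair, and this one shows that the group on this carbon can decide whether any inhibition is read at all. Compound 4 gives > 100000 nM, which is a limit of the assay and not a number: the limit of > 100000 nM in this assay, at which 1 of the 4 values shown sits.

From the compounds shown here alone, whether the nitro group itself is needed stays open. So does whether a chlorine atom, a methyl group or an acetamide on this carbon would stand closer to compound 3 or to compound 4.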